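A few compounds are considered here, and "the series" means these few. Any claim that something is new, unique, unknown or untested is made for them only; others in the source may bear on it.

Working notes on the series. Compound 1, `COC(C)CO[C@H](CC=C(C)C)C1=CC(=O)c2c(O)ccc(O)c2C1=O`, is the starting point; in a functional assay on HeLa cells (Homo sapiens) for cytotoxicity, read by MTT assay (on this read-out higher numbers stand for weaker inhibition and lower numbers for stronger inhibition), compound 1 gives 53400 nM, the second highest of the three numbers in hand. Compound 2, `CC[C@](C)(O)CC(=O)O[C@H](CC=C(C)C)C1=CC(=O)c2c(O)ccc(O)c2C1=O`, gives 30200 nM, and compound 3, `CC(C)=CC[C@@H](OC(=O)CC(C)(O)c1ccccc1)C1=CC(=O)c2c(O)ccc(O)c2C1=O`, gives 85700 nM. The values of compound 1 and compound 3 lie within the scatter of each other, so no order is read between them.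

The change under consideration is the following: (2-hydroxy-2-methylhexyl)carbonyl in place of 2-methoxypropyl on an oxygen on a saturated carbon. This gives compound 4, `CCCCC(C)(O)CC(=O)O[C@H](CC=C(C)C)C1=CC(=O)c2c(O)ccc(O)c2C1=O`. Going by the values given here, the closest precedent is a 1.8-fold lower number from compound 1 to compound 2 (0.25 log units; within the scatter), where a related hydroxylated acyl group took the place of the 2-methoxypropyl group and the number barely moved. The step of a 2.8-fold higher number from compound 2 to compound 3 (0.45 log units; beyond the scatter) shows that altering the substituent on the hydroxylated chain carbon shifts the number only modestly. Since compound 4 differs from compound 2 only in chain length at that position, the expectation in this assay is a small step, a 1.5-fold lower number from compound 1 to compound 4 (0.18 log units; within the scatter), not beyond the scatter. Compound 4 is therefore estimated at 35000 nM, with a range of 15000 nM to 80000 nM.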

Compound 4, half-maximal inhibitory concentration: 60600 nM
For compound 4 the middle estimate is 1.7-fold (0.24 log units) below the measured one; low and high end bracket the measured number.
By their numbers in this assay, from the lowest: compounds 2, 1, 4 and 3 (each within the scatter of the next, the first and the last beyond it).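

In this assay this position accepts (2-hydroxy-2-methylhexyl)carbonyl in place of 2-methoxypropyl with a 1.1-fold higher number from compound 1 to compound 4 (0.05 log units; within the scatter) and no readable change. On the saturated chain carbon, butyl in place of phenyl gives a 1.4-fold lower number from compound 3 to compound 4 (0.15 log units; within the scatter) and 1-hydroxy-1-methylpentyl in place of 1-hydroxy-1-methylpropyl gives a 2.0-fold higher number from compound 2 to compound 4 (0.30 log units; within the scatter), so neither replacement is resolved from the scatter. Compound 4 thus sits inside the span of a 2.8-fold higher number from compound 2 to compound 3 (0.45 log units; beyond the scatter) without a step beyond the scatter on either side, which leaves that earlier step as the only one in the series beyond the scatter.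

As far as these compounds go, whether an amine or a carboxylic acid in this acyl group would move the number beyond the scatter remains open. No measurement of any other kind is at hand to account for these steps.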